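The source may report more compounds than this note shows. Statements on the series, on what has been measured and on what is new or still open speak of the compounds shown alone.

Of the compounds shown here, three sharing one core have been tested in a functional assay on CHO cells for antagonist activity at sphingosine 1-phosphate receptor 2 (Homo sapiens), read by GTPgammaS binding; on this read-out higher numbers stand for weaker inhibition and lower numbers for stronger inhibition. Compound 1, `COc1cc(OC)c(NC(=O)Cc2nn(CC(=O)O)c(=O)c3ccccc23)cc1Cl`, gives 464 nM. Compound 2, `O=C(O)C1(c2nn(Cc3cn4cc(OCC5CC5)c(Cl)cc4n3)c3ccccc3c2=O)CC1`, gives 82 nM. Compound 3, `COc1cc2[nH]c(Cc3nn(CC(=O)O)c(=O)c4ccccc34)nc2cc1Cl`, gives 241 nM. Of the three numbers, compound 3 and compound 1 lie within the usual scatter of each other, so nothing separates them; compound 2 lies below both by a margin beyond the scatter.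

The next compound, compound 4, `O=C(O)Cn1nc(Cc2nc3cc(Cl)c(OC(F)(F)F)cc3[nH]2)c2ccccc2c1=O`, differs from compound 3 in one place: trifluoromethyl in place of methyl on an oxygen on an aromatic ring. For the measured compounds named here, no pair of measured compounds shows what a change like this does on this core, so there is no measured step to lean on, only the fact that compound 3 and compound 1 differ in several places yet end up within the scatter of each other.

With that in mind, compound 4 is expected to stay close to compound 3, with a step of a 1.2-fold lower number from compound 3 to compound 4 (0.08 log units; within the scatter) that may well fall within the scatter. The estimate for compound 4 in this assay is 200 nM, with a likely range from 80 nM to 500 nM.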

Compound 4, half-maximal inhibitory concentration: 342 nM
Compound 4: middle estimate off by 1.7-fold (0.23 log units), on the low side, within the range that was stated.
By their numbers in this assay, from the lowest: compound 2; then compounds 3, 4 and 1 (each within the scatter of the next).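

For the compounds shown here, replacing methoxy with trifluoromethoxy gives the first measured single change on the shared core: in this assay, it produces a 1.4-fold higher number from compound 3 to compound 4 (0.15 log units; within the scatter). On this read-out, methyl and trifluoromethyl on this oxygen therefore cannot be told apart, so this one pair offers no sign that the swap matters for inhibition. The compounds shown offer no measurement that could explain this result.

On these data alone, it remains open whether a longer chain such as ethyl or propyl on this oxygen, or a plain hydroxyl group in place of the methoxy, would also stay within the scatter of compound 3. This single pair also cannot show whether the same swap would have so little effect elsewhere on the molecule or on another core.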